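Swapping the carboxyphenyl arm for a methoxyphenyl arm

A few compounds are considered here, and "the series" means these few. Any claim that something is new, unique, unknown or untested is made for them only; others in the source may bear on it.

Compound 1, `Cc1ccccc1-n1nc(C)c2c1NC(=O)[C@H](C)S[C@@H]2c1ccc(-c2cccc(C(=O)O)c2)cc1`, carries a 3-carboxyphenyl group on its aromatic ring. In an assay on isolated protein for agonist activity at Bile acid receptor (Homo sapiens), read by AlphaScreen, with a stated time of 30 min (a higher number here means that more compound is needed for the effect, a lower number that less compound is needed), compound 1 is recorded as "not active" (no number reported), so no number places it on the potency scale, and it can only be described as having shown no measurable effect. Two related compounds with a shared core do give numbers. Compound 2, `Cc1ccc(-n2nc(C)c3c2NC(=O)[C@H](C)S[C@@H]3c2ccc(Oc3ccccc3)cc2)cc1`, gives 3400 nM in this assay. Compound 3, `Cc1nn(-c2ccccc2C(F)(F)F)c2c1C(c1ccc(Oc3ccccc3)cc1)SC(C)C(=O)N2`, gives 2000 nM in this assay; the two values lie within the usual scatter of each other, so nothing can be said about their order.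

Compound 4, `COc1ccccc1-c1ccc([C@H]2S[C@@H](C)C(=O)Nc3c2c(C)nn3-c2ccccc2C)cc1`, is the compound not yet measured. It differs from compound 1 in one place: 2-methoxyphenyl in place of 3-carboxyphenyl on an aromatic carbon. The 3-carboxyphenyl group, with its hydrogen-bond donor, leaves, and a 2-methoxyphenyl group with one hydrogen-bond acceptor enters on the aromatic carbon para to a large group.

Among the compounds with values here, no step between measured compounds describes this exchange, and compound 1 itself has no number, so the direction is uncertain. Since compound 1 showed no activity, any number for compound 4 would be an improvement, but the gap cannot be sized. Compound 4 is expected to give about 6000 nM in this assay, estimated within 1500 nM to 25000 nM, with a real chance that only a limit is reported.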

Compound 4, half-maximal effective concentration: 1100 nM
Compound 4: middle estimate off by 5.5-fold (0.74 log units), on the high side; measured number outside the range, below it.
By their numbers in this assay, from the lowest: compounds 4, 3 and 2 (each within the scatter of the next, the first and the last beyond it).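

Compound 1 has no number, so the change from compound 1 to compound 4, which gives 1100 nM in this assay, cannot be read as a step. No measurement shown accounts for this result. The compounds shown leave open whether the activity of compound 4 depends on the 2-methoxyphenyl group itself or would persist with other groups in that place.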